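Chalcone series: methyl for hydroxy hydrogen and cell inhibition

The compounds below may be only part of what the source reports. "The series", "measured", "known", "first", "only" and "open" are said of these compounds alone.

Measured so far, in a functional assay on HeLa cells (Homo sapiens) for inhibition, read by MTT assay, with a stated time of 72 h; on this read-out lower numbers stand for stronger inhibition and higher numbers for weaker inhibition:
Compound 1, `COc1cc(/C=C/C(=O)c2c(OC)cc(O)c(CC=C(C)C)c2O)ccc1O`, gives 33800 nM.
Compound 2, `COc1ccc(/C=C/C(=O)c2c(OC)cc(O)c(CC=C(C)C)c2O)cc1OC`, gives 27700 nM.
Compound 3, `COc1cc(OC)c(C(=O)/C=C/c2ccc(O)c(O)c2)c(OC)c1`, gives 15800 nM.

Compound 1 and compound 2 share a core and differ by methyl in place of hydrogen on an oxygen on an aromatic ring; this change gave a 1.2-fold lower number from compound 1 to compound 2 (0.09 log units; within the scatter). Compound 3 carries a different core, and how its core differs from that of compound 1 is not broken down here. Its value in this assay is the lowest of the three, but the gap to compound 2 lies within the scatter, so no order between them is claimed; only the gap to compound 1 lies beyond it.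

Compound 4, `COc1cc(OC)c(C(=O)/C=C/c2ccc(O)c(OC)c2)c(OC)c1`, is not yet measured. It differs from compound 3 by methyl in place of hydrogen on an oxygen on an aromatic ring, the same change, at the same kind of place, as seen from compound 1 to compound 2. Among the measured compounds shown here, only this one prior instance of the change is available, on a different core. Because a 1.2-fold lower number from compound 1 to compound 2 (0.09 log units; within the scatter) was within the scatter, a step of about the same size is expected here, a 1.1-fold lower number from compound 3 to compound 4 (0.05 log units; within the scatter), and the value of compound 4 in this assay is estimated at 14000 nM, most likely between 5000 nM and 40000 nM.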

Compound 4, half-maximal inhibitory concentration: 44900 nM
Estimate against measurement, compound 4: 3.2-fold (0.51 log units) below, outside the stated range (above it).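

In this assay, methyl in place of hydrogen on an oxygen on an aromatic ring gave a 2.8-fold higher number from compound 3 to compound 4 (0.45 log units; beyond the scatter). The size of this step therefore does not carry from one core to the other in this series, since the two steps differ by more than the scatter: the same change on two cores in this assay, a 1.2-fold lower number (0.09 log units; within the scatter) from compound 1 to compound 2 and a 2.8-fold higher number (0.45 log units; beyond the scatter) from compound 3 to compound 4, 3.5-fold (0.54 log units) apart, beyond the scatter of two such steps This shows that a step read on the core of compound 1 was a poor guide on the core of compound 3, but with a single pair on each core, it does not show which part of the cores accounts for the difference, nor does it give a rule for any further core.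

The compounds shown leave open what a longer chain on the same oxygen, such as ethyl or propyl, would do on either core. They also leave open whether an amine or a carboxylic acid in place of the hydroxy would give steps that agree between the two cores.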